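Phenyl Returns to the Triazole: Estimating Compound 4

The source may hold more compounds than are shown below. What is called first, only, known or untested is meant among the compounds shown, and "the series" means these compounds.

Measured compounds:
Compound 1, `O=C1O[C@H]([C@@H](O)Cn2cc(-c3ccc(Br)cc3)nn2)C(OCc2ccccc2)=C1OCc1ccccc1`: 5070 nM
Compound 2, `CC(C)(C)c1cn(C[C@H](O)[C@H]2OC(=O)C(OCc3ccccc3)=C2OCc2ccccc2)nn1`: 29200 nM
Compound 3, `O=C1O[C@H]([C@@H](O)Cn2cc(C3CC3)nn2)C(OCc2ccccc2)=C1OCc1ccccc1`: 38100 nM

All three were read in a functional assay on HepG2 cells (Homo sapiens) for antiproliferative activity, read by MTT assay, with a stated time of 72 h; a lower number here means a stronger inhibitor, a higher number a weaker inhibitor. Compound 3 carries the highest of the three numbers; its gap to compound 2 is within the scatter, whereas the step of a 7.5-fold higher number from compound 1 to compound 3 (0.88 log units; beyond the scatter) is beyond it.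

Compound 4, `Cc1ccc(-c2cn(C[C@H](O)[C@H]3OC(=O)C(OCc4ccccc4)=C3OCc3ccccc3)nn2)cc1`, arises from compound 3 by 4-methylphenyl in place of cyclopropyl on an aromatic carbon. Among the measured compounds shown here, two measured steps bear on this change: a 7.5-fold higher number from compound 1 to compound 3 (0.88 log units; beyond the scatter) and a 5.8-fold higher number from compound 1 to compound 2 (0.76 log units; beyond the scatter), where a 4-bromophenyl gave way to a small saturated group and the number rose. Here the reverse occurs, so compound 4 is expected to show a lower number, an expected step of a 5.9-fold lower number from compound 3 to compound 4 (0.77 log units; beyond the scatter). Compound 4 is therefore estimated at 6500 nM, within the range 2500 nM to 17000 nM.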

Compound 4, half-maximal inhibitory concentration: 8770 nM
The estimate for compound 4 lay 1.3-fold (0.13 log units) below the measured number; measured number inside the range.
By their numbers in this assay, from the lowest: compounds 1 and 4 (each within the scatter of the next); then compounds 2 and 3 (each within the scatter of the next).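

In this assay, the lower numbers seen with 4-bromophenyl on this aromatic carbon are no longer tied to a single aryl group: 4-methylphenyl in place of cyclopropyl gives (a 4.3-fold lower number from compound 3 to compound 4 (0.64 log units; beyond the scatter)), and in place of tert-butyl gives (a 3.3-fold lower number from compound 2 to compound 4 (0.52 log units; beyond the scatter)). Methyl in place of bromo gives (a 1.7-fold higher number from compound 1 to compound 4 (0.24 log units; within the scatter)), so bromo is not required at this level of activity. No measurement shown explains these differences.

The compounds shown leave open how an amine or a carboxylic acid in place of that methyl would read in this assay.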